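From hydroxy to methyl on a growth inhibitor

The compounds below may be only part of what the source reports. "The series", "measured", "known", "first", "only" and "open" are said of these compounds alone.

Compound 1 `Cc1ccc2[nH]c(-c3ccc(-c4ccc(-c5ccc(N(C)C)cc5)cc4)cc3)nc2c1`: 3510 nM
Compound 2 `FC(F)(F)c1ccc(-c2ccc(-c3ccc(-c4nc5ccccc5[nH]4)cc3)cc2)cc1`: 36600 nM
Compound 3 `Oc1cccc2[nH]c(-c3ccc(-c4ccc(-c5ccc(C(F)(F)F)cc5)cc4)cc3)nc12`: 3610 nM

In a functional assay on A549 cells (Homo sapiens) for inhibition, read by sulforhodamine B assay (on this read-out higher numbers stand for weaker inhibition of growth and lower numbers for stronger inhibition of growth), compound 3 holds the second highest of the three numbers, although its value lies within the usual scatter of that of compound 1. Compound 4 `Cc1ccc2[nH]c(-c3ccc(-c4ccc(-c5ccc(C(F)(F)F)cc5)cc4)cc3)nc2c1` has not yet been measured. Its structure differs from that of compound 3 as follows: 5-methyl-1H-benzimidazol-2-yl in place of 4-hydroxy-1H-benzimidazol-2-yl on an aromatic carbon.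

The measured step that bears most directly on this change is a 10-fold lower number from compound 2 to compound 3 (1.01 log units; beyond the scatter), which is large and comes with hydroxy in place of hydrogen on an aromatic carbon. Compound 4 lacks that hydroxy, so a higher number is expected, though the size of the rise is uncertain. Within the data shown here, no measured step tests the methyl alone. Compound 1 carries the same 5-methyl-1H-benzimidazol-2-yl and gives 3510 nM, but it differs elsewhere too.

In this assay, the expected change is a 3.9-fold higher number from compound 3 to compound 4 (0.59 log units; beyond the scatter). For compound 4, the estimate is 14000 nM, with an expected range of 4500 nM to 40000 nM.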

Compound 4, concentration for 50% growth inhibition: 3520 nM
For compound 4 the middle estimate is 4.0-fold (0.60 log units) above the measured one; measured number below the stated range.
By their numbers in this assay, from the lowest: compounds 1, 4 and 3 (each within the scatter of the next); then compound 2.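

In this assay, putting 5-methyl-1H-benzimidazol-2-yl in place of 4-hydroxy-1H-benzimidazol-2-yl gives a 1.0-fold lower number from compound 3 to compound 4 (0.01 log units; within the scatter), so the hydroxy is not needed to hold this level of growth inhibition. Methyl in place of hydrogen gives a 10-fold lower number from compound 2 to compound 4 (1.02 log units; beyond the scatter), a large step beyond the scatter, just as hydroxy in place of hydrogen gave a 10-fold lower number from compound 2 to compound 3 (1.01 log units; beyond the scatter), so among these compounds a gain from a small group on the benzimidazole is not unique to hydroxy. Trifluoromethyl in place of dimethylamino gives a 1.0-fold higher number from compound 1 to compound 4 (0.00 log units; within the scatter), so with the methyl present, these two groups at the far end cannot be told apart.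

No measurement shown explains why either small group has this effect. Going by these compounds, whether an amine or a longer chain, such as ethyl, on the benzimidazole would do the same remains open.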